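Aryl amide series: methyl in place of bromo

A few compounds are considered here, and "the series" means these few. Any claim that something is new, unique, unknown or untested is made for them only; others in the source may bear on it.

Measured so far in an assay on isolated protein for inhibition of glutathione S-transferase P (Homo sapiens), with a stated time of 10 min; on this read-out lower numbers stand for stronger inhibition and higher numbers for weaker inhibition:
Compound 1 `O=C(CCC(=O)OCCCCCCSc1ccc([N+](=O)[O-])c2nonc12)Nc1ccccc1` gives 10200 nM.
Compound 2 `O=C(CCC(=O)OCCCCCCSc1ccc([N+](=O)[O-])c2nonc12)Nc1ccc(Br)cc1` gives 5090 nM.

In this assay, among the measured compounds shown here, compound 2 holds the lowest of the two numbers; its only neighbour is compound 1, and the step of a 2.0-fold lower number from compound 1 to compound 2 (0.30 log units; within the scatter) lies within the scatter. Compound 3 `Cc1ccc(NC(=O)CCC(=O)OCCCCCCSc2ccc([N+](=O)[O-])c3nonc23)cc1` is not yet measured. It differs from compound 2 by methyl in place of bromo on an aromatic carbon. For the measured compounds named here, the one measured step that touches this position is a 2.0-fold lower number from compound 1 to compound 2 (0.30 log units; within the scatter), hydrogen to bromo, and it stayed within the scatter. Going by the values given here, no measured pair sets methyl against bromo directly, so no direction is supported by the data. For compound 3 a step in this assay of no more than the scatter is therefore expected, summarised as a 1.4-fold higher number from compound 2 to compound 3 (0.14 log units; within the scatter). The estimate for compound 3 is 7000 nM, with a range from 3500 nM to 14000 nM.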

Compound 3, half-maximal inhibitory concentration: 6800 nM
Compound 3: middle estimate off by 1.0-fold (0.01 log units), on the high side, within the range that was stated.
By their numbers in this assay, from the lowest: compounds 2, 3 and 1 (each within the scatter of the next).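

In this assay, among the compounds shown here, the change from 4-bromophenyl to 4-methylphenyl gives a 1.3-fold higher number from compound 2 to compound 3 (0.13 log units; within the scatter), the first direct reading of methyl against bromo on this aromatic carbon para to a large group. Methyl in place of hydrogen gives a 1.5-fold lower number from compound 1 to compound 3 (0.18 log units; within the scatter), so both substituents can now be read against hydrogen, and hydrogen, bromo and methyl at this position all remain within the scatter of one another. No supporting data bear on this result.

As far as these compounds go, whether an amine, a carboxylic acid or a methoxy group on this carbon would give a step beyond the scatter remains open. For the compounds shown here, also open is whether a longer chain in place of the one in compound 1 would alter the number in this assay.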